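Amide substituent series on a shared core: diacid analogue

The source may hold more compounds than are shown below. What is called first, only, known or untested is meant among the compounds shown, and "the series" means these compounds.

Three compounds with a shared core and varied amide substituents have been measured in a functional assay on PC-3 cells (Homo sapiens) for antiproliferative activity, read by MTT assay, with a stated time of 24 h; a higher number here means a weaker inhibitor, a lower number a stronger inhibitor. Compound 1 `CCn1c(C(=O)N[C@@H](CC(=O)OC)C(=O)OC)ccc1C(CC)(CC)c1ccc(OCS(=O)(=O)c2ccccc2)c(C)c1` gives 6490 nM. Compound 2 `CCn1c(C(=O)N[C@H](CO)CCO)ccc1C(CC)(CC)c1ccc(OCS(=O)(=O)c2ccccc2)c(C)c1` gives 12100 nM. Compound 3 `CCn1c(C(=O)N[C@@H](CO)CCCO)ccc1C(CC)(CC)c1ccc(OCS(=O)(=O)c2ccccc2)c(C)c1` gives 13400 nM, the highest of the three numbers; its nearest neighbour is compound 2, its furthest compound 1. The step of a 2.1-fold higher number from compound 1 to compound 3 (0.31 log units; beyond the scatter) is the only one here beyond the scatter, while a 1.1-fold higher number from compound 2 to compound 3 (0.04 log units; within the scatter) and a 1.9-fold higher number from compound 1 to compound 2 (0.27 log units; within the scatter) both fall inside it.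

Compound 4 `CCn1c(C(=O)N[C@H](CCC(=O)O)C(=O)O)ccc1C(CC)(CC)c1ccc(OCS(=O)(=O)c2ccccc2)c(C)c1` is not yet measured. Relative to compound 3 the change is a group of 9 heavy atoms (5 carbon, 4 oxygen; no ring) in place of a group of 7 heavy atoms (5 carbon, 2 oxygen; no ring), on an amide-type nitrogen. The measured steps on this amide nitrogen show only a narrow spread: the two diol-type chains sit together, and the diester chain of compound 1 lies a modest distance lower. The incoming 1,3-dicarboxypropyl group shares the two carbonyl oxygens of compound 1 and the two hydrogen-bond donors of compound 3, so no strong direction is indicated. A small step in this assay, most likely downward but within the scatter, is expected, a 1.5-fold lower number from compound 3 to compound 4 (0.17 log units; within the scatter). Compound 4 is therefore estimated at 9000 nM, with a range from 3000 nM to 30000 nM.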

Compound 4, half-maximal inhibitory concentration: > 50000 nM
Compound 4 was reported as a limit; the forecaster's own chance of this, stated with the estimate: 10%; at least 5.5-fold (0.74 log units) between middle value and limit.
By their numbers in this assay, from the lowest: compounds 1, 2 and 3 (each within the scatter of the next, the first and the last beyond it). At a limit, above all of these: compound 4.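

In this assay, for the compounds shown here, compound 4 is reported only as a limit, the one value of the series so placed: the limit of > 50000 nM in this assay, at which 1 of the 4 values shown sits. The earlier groups on this amide-type nitrogen spanned only a modest range, whereas 1,3-dicarboxypropyl gives an at least 3.7-fold higher number from compound 3 to compound 4 (0.57 log units; beyond the scatter), together with an at least 4.1-fold higher number from compound 2 to compound 4 (0.61 log units; beyond the scatter) and an at least 7.7-fold higher number from compound 1 to compound 4 (0.88 log units; beyond the scatter), so the position is less tolerant of change than compounds 1, 2 and 3 alone suggested. The counts of hydrogen-bond donors and acceptors are the same for the groups of compound 3 and compound 4, and neither group carries a net charge, so these counts do not separate the two results.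

The compounds shown do not tell whether the step follows the two carboxylic acids themselves or the chain that carries them, since the diester of compound 1 is built on an ethyl chain and the diacid of compound 4 on a propyl chain. The matching diester, 1,3-bis(methoxycarbonyl)propyl, or a chain with a single carboxylic acid and a single methyl ester, would bear on that question.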